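Lengthening the Amide Carbonyl Substituent with a Vinyl Spacer

The source may hold more compounds than are shown below. What is called first, only, known or untested is meant among the compounds shown, and "the series" means these compounds.

Among the measured compounds shown here, compound 2 `O=C(Nc1cc(Sc2ncn[nH]2)c(O)c2ccccc12)c1ccc(Cl)cc1` gives 25700 nM in a functional assay on MDA-MB-231 cells (Homo sapiens) for antiproliferative activity, read by MTT assay, with a stated time of 48 h (a lower number here means a stronger inhibitor, a higher number a weaker inhibitor), the only number among the values shown. Compound 1 `COc1ccc(C(=O)Nc2cc(Sc3ncn[nH]3)c(O)c3ccccc23)cc1` reaches only a limit in this assay, namely > 100000 nM. For the measured compounds named here, the step of an at least 3.8-fold lower number from compound 1 to compound 2 (0.59 log units; beyond the scatter) is the single measured change, and its size can only be bounded, since it rests on (the limit of > 100000 nM in this assay, at which 1 of the 2 values shown sits). Compound 3 `O=C(/C=C/c1ccc(Cl)cc1)Nc1cc(Sc2ncn[nH]2)c(O)c2ccccc12` differs from compound 2 by 2-(4-chlorophenyl)ethenyl in place of 4-chlorophenyl on a carbonyl carbon. Going by the values given here, no measured step touches the carbonyl side of the amide; the one measured step concerns the substituent on the aromatic ring, and the chloro that enters there is kept in compound 3. There is thus no measured basis to expect a shift beyond the scatter in this assay in either direction. Compound 3 is therefore estimated at 20000 nM, within a range from 6000 nM to 70000 nM, which means an expected step of a 1.3-fold lower number from compound 2 to compound 3 (0.11 log units; within the scatter).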

Compound 3, half-maximal inhibitory concentration: > 100000 nM
Compound 3 ended at the assay's limit; the forecaster's own chance of this, stated with the estimate: 15%; middle value at least 5.0-fold (0.69 log units) from the limit.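

Moving from 4-chlorophenyl to 2-(4-chlorophenyl)ethenyl on the carbonyl carbon gives an at least 3.8-fold higher number from compound 2 to compound 3 (0.59 log units; beyond the scatter) in this assay, so this position, untouched by the earlier step, does respond to change, and here the change costs activity. The chloro on the aromatic ring is kept in compound 3, so that group alone does not preserve the level of compound 2 once the vinyl spacer enters. Compound 3 gives a limit, not a number, so the size of that step is only a bound, and the step between compound 1 and compound 3 cannot be read: the limit of > 100000 nM in this assay, at which 2 of the 3 values shown sit.

The compounds shown do not separate the double bond from the added length. They also leave open whether a saturated chain in its place, or an amine on the aromatic ring in place of the chloro, would bring activity back in this assay.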